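Benzyl in Place of Phenyl on the Saturated Ring Carbon

A few compounds are considered here, and "the series" means these few. Any claim that something is new, unique, unknown or untested is made for them only; others in the source may bear on it.

Measured compounds:
- compound 1, `CC(C)(C)OC(=O)N1CCN(C(=O)n2cc(-c3ccc(OC(F)(F)F)cc3)nn2)C(c2ccccc2)C1`, giving 20 nM in an assay on membranes from brain for inhibition of Monoacylglycerol lipase ABHD6 (Mus musculus), with a stated time of 30 min; on this read-out lower numbers stand for stronger inhibition and higher numbers for weaker inhibition
- compound 2, `C#CCO[C@@H]1CC[C@H](Cc2ccccc2)N(C(=O)n2ncc(C(O)(c3ccc(F)cc3)c3ccc(F)cc3)n2)C1`, giving 126 nM in this assay

Compound 1 stands at the lowest of the two numbers available in this assay, and its nearest neighbour is compound 2, whose number lies well beyond the scatter of repeated measurements above it. The two share no single-point difference, so their values are compared only as they stand; compound 2 also carries a benzyl group on a saturated ring carbon, but on a different core, and nothing can be drawn from that.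

Compound 3, `CC(C)(C)OC(=O)N1CCN(C(=O)n2cc(-c3ccc(OC(F)(F)F)cc3)nn2)C(Cc2ccccc2)C1`, has not been measured. It differs from compound 1 in one place: benzyl in place of phenyl on a saturated ring carbon. For the measured compounds named here, no pair of measured compounds shows this exact change, so no measured step guides the expectation, which therefore leans on compound 1 alone.

Compound 3 is expected to sit close to compound 1, with the step of a 1.8-fold higher number from compound 1 to compound 3 (0.24 log units; within the scatter) estimated as a modest move toward a higher number that may well stay within the scatter. The estimate for compound 3 in this assay is 35 nM, with a range from 8 nM to 150 nM.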

Compound 3, half-maximal inhibitory concentration: 79 nM
Estimate against measurement, compound 3: 2.3-fold (0.35 log units) below; the measured number falls inside the stated range.
By their numbers in this assay, from the lowest: compound 1; then compounds 3 and 2 (each within the scatter of the next).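

In this assay the saturated ring carbon next to the ring nitrogen proves responsive to even this small change: benzyl in place of phenyl gives a 4.0-fold higher number from compound 1 to compound 3 (0.60 log units; beyond the scatter) and moves inhibition in the weaker direction, with the ring type and the donor and acceptor counts of the group unchanged. For the compounds shown here, this is the first measured step at this position, and it places the directly attached phenyl of compound 1 ahead of the benzyl of compound 3 on the shared core, so the position does not accept the two groups as equivalent. Nothing measured here accounts for the size or the direction of this step.

Going by these compounds alone, with only this one step at the position, it remains open whether the trend continues with a longer chain such as phenethyl, or whether a smaller group such as methyl, or a fluorine on the phenyl ring, would hold or lower the number of compound 1. From the compounds shown here alone, it also remains open whether the same exchange would have a similar effect with another group in place of the tert-butoxycarbonyl group or the 4-(trifluoromethoxy)phenyl group on the core.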